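Double-bond geometry: from compound 2 to compound 3

This account rests on a few compounds, and the source may have more. Where it says the series, first, only, none or still open, it means among the compounds named here.

In a functional assay on PC-3 cells (Homo sapiens) for antiproliferative activity, read by WST assay, with a stated time of 72 h (a lower number here means that less compound is needed, a higher number that more compound is needed for the effect), compound 2 (`CCCCCCCC/C=C\c1c(C)c(/C=C/CCCCCCCC)c(C)[n+]2c1CCC2`) gives 0.7 uM within the scatter of compound 1 (`CCCCCCCC/C=C/c1c(C)c(/C=C/CCCCCCCC)c2[n+](c1C)CCC2`) at 0.6 uM in the same read-out. Compound 3 (`CCCCCCCC/C=C\c1c(C)c(/C=C/CCCCCCCC)c2[n+](c1C)CCC2`) relates to compound 2 as follows: the two compounds have the same atoms and bonds and differ only in configuration as drawn: 2 of 2 stereo elements differ; a double bond is drawn E in compound 2 and Z in compound 3; a double bond is drawn Z in compound 2 and E in compound 3 and no atoms leave or enter. Within the data shown here, with the fact that compounds 1 and 2 differ only in the configuration as drawn in view, the one measured guide is a 1.2-fold higher number from compound 1 to compound 2 (0.07 log units; within the scatter) and it concerns a single double bond, whereas this change concerns both. No shift beyond the scatter is expected in this assay on that evidence. An estimated 1.1-fold lower number from compound 2 to compound 3 (0.03 log units; within the scatter) is expected here. The estimate for compound 3 is 0.65 uM with an expected range from 0.3 uM to 1.4 uM in this read-out.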

Compound 3, concentration for half-maximal effect: 0.5 uM
Beside the measured number, compound 3's estimate is 1.3-fold (0.11 log units) above it; measured number inside the range.
By their numbers in this assay, from the lowest: compounds 3, 1 and 2 (each within the scatter of the next).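

In this assay, changing the geometry at both double bonds gives a 1.4-fold lower number from compound 2 to compound 3 (0.15 log units; within the scatter), and changing a single double bond gives a 1.2-fold lower number from compound 1 to compound 3 (0.08 log units; within the scatter). Neither the change at both double bonds nor this second single change leaves the scatter, so compounds 1, 2 and 3 stay together whichever double-bond geometry is drawn. The reading concerns configuration alone: the fact that compounds 2 and 3 differ only in the configuration as drawn

What the compounds shown leave open is how far this tolerance depends on the chains themselves. A saturated chain, a shorter chain or a chain carrying a carboxylic acid might not behave the same way.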